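A Cyano Substituent Carried From One Core to Another

A few compounds are considered here, and "the series" means these few. Any claim that something is new, unique, unknown or untested is made for them only; others in the source may bear on it.

Compound 1 `O=C(N1CCCN(Cc2ccc(OCc3ccccc3)cc2)CC1)n1cccn1` and compound 2 `N#Cc1cnn(C(=O)N2CCCN(Cc3ccc(OCc4ccccc4)cc3)CC2)c1` share one core. In an assay on membranes from brain for binding affinity to Monoacylglycerol lipase ABHD6 (Mus musculus), read by fluorescence, with stated times of 1 h and 30 min (on this read-out higher numbers stand for weaker inhibition and lower numbers for stronger inhibition), compound 1 gives 960 nM and compound 2 gives 85 nM. The change between them, (cyano in place of hydrogen on an aromatic carbon), brought an 11-fold lower number from compound 1 to compound 2 (1.05 log units; beyond the scatter). Compound 3 `CN(CCN(C)C(=O)n1cccn1)Cc1cccc(OCc2ccccc2)c1` rests on a different core; the difference between the two cores is not broken down here. In this assay compound 3 gives 5500 nM, the highest of the three numbers. Compound 4 `CN(CCN(C)C(=O)n1cc(C#N)cn1)Cc1cccc(OCc2ccccc2)c1` carries the same change on the core of compound 3, (cyano in place of hydrogen on an aromatic carbon), and the surroundings of the place read alike word for word. Compound 4 is expected to make an 11-fold lower number from compound 3 to compound 4 (1.04 log units; beyond the scatter) because an 11-fold lower number from compound 1 to compound 2 (1.05 log units; beyond the scatter) came from this very change. The estimated value for compound 4 is 500 nM, with a likely range from 200 nM to 1500 nM.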

Compound 4, half-maximal inhibitory concentration: 1100 nM
Beside the measured number, compound 4's estimate is 2.2-fold (0.34 log units) below it, and the stated range covers the measured number.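

In this assay the same cyano change on the second core gave a 5.0-fold lower number from compound 3 to compound 4 (0.70 log units; beyond the scatter), a step in the same direction as the earlier one. The two steps do not separate in size: the same change on two cores in this assay, an 11-fold lower number (1.05 log units; beyond the scatter) from compound 1 to compound 2 and a 5.0-fold lower number (0.70 log units; beyond the scatter) from compound 3 to compound 4, 2.3-fold (0.35 log units) apart, within the scatter of two such steps. This shows that the change carried across these two cores in this assay, but two pairs cannot show that it would carry to any other core, and they do not explain why the number falls.

Going by these compounds, it remains open whether a chlorine, a primary amide or a carboxylic acid on the same aromatic carbon would act as the cyano does. On these data alone, it also remains open whether the cyano step would hold on a core with a longer chain.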